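The source may report more compounds than this note shows. Statements on the series, on what has been measured and on what is new or still open speak of the compounds shown alone.

Three compounds sharing one core were tested in a functional assay on the whole organism (Abdomen, strain Swiss) for inhibition, with Mus musculus as the target, with stated times of 30 min, 10 min and 5 min, at a dose of 40 mg/kg by the oral route; a lower number here means a weaker effect, a higher number a stronger effect of the compound at the dose given. Compound 1 `CCc1nn(CCCN2CCN(c3ccc(C)cc3)CC2)c(=O)c(N)c1C(C)=O` gives 41%. Compound 2 `CCC(=O)c1c(C)nn(CCCN2CCN(c3ccc(C)cc3)CC2)c(=O)c1N` gives 29%. Compound 3 `C=Cc1c(CC)nn(CCCN2CCN(c3ccc(C)cc3)CC2)c(=O)c1N` gives 28%, which sits beyond the scatter below compound 1, while its gap to compound 2 lies within the scatter. Among the measured compounds shown here, the only single-point step measured, a number 13 percentage points lower from compound 1 to compound 3 (beyond the scatter), concerns a different group on the core. Compound 4 `C=Cc1c(CCC)nn(CCCN2CCN(c3ccc(C)cc3)CC2)c(=O)c1N` differs from compound 3 by methyl in place of hydrogen on a saturated chain carbon, two bonds along the chain from an aromatic carbon. For the measured compounds named here, no measured step touches this chain, so nothing in the data points in either direction, and the expected step of no change at the digits printed from compound 3 to compound 4 (within the scatter) is none beyond the scatter. Compound 4 is therefore estimated to give about 28%, with a likely range between 14% and 42%.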

Compound 4, a percentage reported as inhibition, in the whole organism at one dose (the size of the read-out at that dose, not a potency): 22%
Beside the measured number, compound 4's estimate is 6 percentage points above it, and the stated range covers the measured number.
By their numbers in this assay, from the lowest: compounds 4, 3 and 2 (each within the scatter of the next); then compound 1.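

Ethyl becoming propyl is the first change at this chain that can be read, and in this assay it gives a number 6 percentage points lower from compound 3 to compound 4 (within the scatter). One added methyl at this place on the saturated chain therefore moves the read-out no further than repeat measurements usually do, unlike the earlier change from acetyl to vinyl. Nothing available gives a reason for this result.

On these data alone, whether a butyl chain, a branched isopropyl group or a chain ending in an amine would shift the read-out beyond the scatter remains open.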